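The compounds below may be only part of what the source reports. "The series", "measured", "known", "first", "only" and "open" are said of these compounds alone.

Measured so far in an ADME assay on the whole organism for inhibition, with Echinochloa crus-galli var. formosensis as the target, with a stated time of 4 days; on this read-out higher numbers stand for weaker inhibition and lower numbers for stronger inhibition:
- compound 1 `CCNc1nc(Cl)nc(N[C@H](C)c2ccccc2)n1` gives 2690 nM
- compound 2 `C[C@H](Nc1nc(Cl)nc(NC(C)(C)C)n1)c1ccccc1` gives 7410 nM
- compound 3 `CNc1nc(Cl)nc(N[C@H](C)c2ccccc2)n1` gives 562 nM

Compound 3 differs from compound 1 only by hydrogen in place of methyl on a saturated chain carbon bound to a nitrogen on an aromatic ring, and that step gave a 4.8-fold lower number from compound 1 to compound 3 (0.68 log units; beyond the scatter). Compound 4 `CC(C)Nc1nc(Cl)nc(N[C@@H](C)c2ccccc2)n1` has not been measured; it differs from compound 2 by hydrogen in place of methyl on a saturated chain carbon bound to a nitrogen on an aromatic ring and two saturated chain carbons. The place is not word for word the same, since in compound 2 the carbon carrying the methyl is also bound to two saturated chain carbons, so this is the same kind of change rather than the same change. The difference between the cores of compound 1 and compound 2 is not broken down here. Compound 2 gives the highest number of the three. For compound 4 a step of about a 3.0-fold lower number from compound 2 to compound 4 (0.47 log units; beyond the scatter) is expected, resting on compound 1 and a 4.8-fold lower number from compound 1 to compound 3 (0.68 log units; beyond the scatter). Compound 4 is therefore estimated at 2500 nM, likely between 900 nM and 7000 nM.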

Compound 4, half-maximal inhibitory concentration: 11000 nM
Estimate against measurement, compound 4: 4.4-fold (0.64 log units) below; the whole stated range lies below it.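

In this assay, going from tert-butyl to isopropyl gives a 1.5-fold higher number from compound 2 to compound 4 (0.17 log units; within the scatter), so on this core, removing the methyl has no effect that can be told from the usual scatter. Among these compounds, removing a methyl therefore did not carry over as the same step from one core to the other: the same change on two cores in this assay, a 4.8-fold lower number (0.68 log units; beyond the scatter) from compound 1 to compound 3 and a 1.5-fold higher number (0.17 log units; within the scatter) from compound 2 to compound 4, 7.1-fold (0.85 log units) apart, beyond the scatter of two such steps With only two pairs, this shows that a step measured on one core cannot simply be transferred to another here, but it does not show why the steps differ or how the change would behave on any further core.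

The compounds shown leave open what a longer chain such as n-butyl, or a ring such as cyclopropyl, would give on the amino group. They also leave open how a plain amino group would compare.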